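The source may report more compounds than this note shows. Statements on the series, on what has been measured and on what is new or still open speak of the compounds shown alone.

Measured in an ADME assay on CHO cells (Cricetulus griseus) for cytotoxicity, read by LDH release; on this read-out higher numbers stand for weaker inhibition and lower numbers for stronger inhibition:
Compound 1 `CC(Sc1ccc(Cl)cc1Cl)C(=O)NCc1ccc(F)cc1`: > 100000 nM
Compound 2 `CC(Oc1ccc(Cl)cc1Cl)C(=O)Nc1ccc(F)cc1`: "not determined" (no result reported)
Compound 3 `CC(Oc1ccc(Cl)cc1Cl)C(=O)NCc1ccccc1`: 95000 nM

Of these three compounds, only compound 3 has an actual number, 95000 nM, so it can be ranked against neither of the others. Compound 1 gives > 100000 nM, which is a limit of the assay and not a number. Compound 2 has no reported result, which leaves compound 3 as the only firm reference point in this assay.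

The next compound is compound 4 `CC(Oc1ccc(Cl)cc1Cl)C(=O)NCc1cccc(Cl)c1`. It keeps the structure of compound 3 except for chloro in place of hydrogen on an aromatic carbon, meta to a large group, so that phenyl becomes 3-chlorophenyl: chloro in place of hydrogen on an aromatic carbon.

Among the measured compounds shown here, no two measured compounds differ in one place only, so the data offer no direct precedent for this change. A small move toward lower numbers in this assay is expected, meaning somewhat stronger inhibition, though a result within the usual scatter of compound 3 at 95000 nM would be unsurprising. The expected step of a 1.5-fold lower number from compound 3 to compound 4 (0.16 log units; within the scatter) is therefore modest. Compound 4 is estimated at 65000 nM, with an expected range from 28000 nM to 100000 nM.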

Compound 4, half-maximal inhibitory concentration: 19000 nM
Beside the measured number, compound 4's estimate is 3.4-fold (0.53 log units) above it; the whole stated range lies above it.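

Chloro in place of hydrogen on an aromatic carbon, which turns phenyl into 3-chlorophenyl, gives a 5.0-fold lower number from compound 3 to compound 4 (0.70 log units; beyond the scatter) in this assay, and this is the first comparison in the series between compounds that differ in one place. It shows that this ring, at the place meta to a large group, is not indifferent to substitution on this read-out: a single chlorine atom, bringing no hydrogen-bond donor or acceptor and no net charge, moves the number toward stronger inhibition by more than the scatter. It also gives the series a value well clear of the top of the measurable range, leaving room to read further changes on this ring in either direction, which compound 3 offered far less of: the limit of > 100000 nM in this assay, at which 1 of the 4 values shown sits.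

Going by these compounds, whether a methoxy group, a nitrile or an amine at the same place would move the number the same way, or whether the step belongs to chloro alone, remains open. A single step also cannot tell whether chloro elsewhere on this ring would act alike.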